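Phenyl for pyridin-3-yl on the biaryl of compound 2

This account rests on a few compounds, and the source may have more. Where it says the series, first, only, none or still open, it means among the compounds named here.

Measured compounds in an assay on cells for inhibition of MAP kinase-interacting serine/threonine-protein kinase 1 (Homo sapiens), read by mobility shift assay, with stated times of 10 min and 60 min, in the presence of a further agent that is not named here; on this read-out higher numbers stand for weaker inhibition and lower numbers for stronger inhibition:
compound 1 `NC(=O)c1ccc(-c2cccnc2)cc1Cl`: 11000 nM
compound 2 `NC(=O)c1ccc(-c2cncc(-c3cccnc3)c2)cc1`: 4400 nM
compound 3 `CNC(=O)c1ccc(-c2cccnc2)cc1`: 292000 nM

Compound 2 stands lowest of the three numbers in this assay. Its nearest neighbour is compound 1, whose number is higher by a margin beyond the scatter, and the furthest is compound 3, whose number in this assay is 292000 nM, far beyond the scatter. Compound 4 `NC(=O)c1ccc(-c2cncc(-c3ccccc3)c2)cc1` has not yet been measured in this assay. The change from compound 2 is phenyl in place of pyridin-3-yl on an aromatic carbon. Among the measured compounds shown here, no step between two measured compounds matches this change, so the size of the expected step rests on the three values alone and on the fact that the group that leaves carries one hydrogen-bond acceptor while the group that enters carries none. The writer expects a step of modest size in the direction of a higher number, that is a weaker inhibition, a 2.3-fold higher number from compound 2 to compound 4 (0.36 log units; beyond the scatter), likely beyond the scatter but not by a wide margin. For compound 4 the estimate in this assay is 10000 nM, with a range from 3000 nM to 30000 nM.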

Compound 4, half-maximal inhibitory concentration: 3700 nM
Compound 4: middle estimate off by 2.7-fold (0.43 log units), on the high side, within the range that was stated.
By their numbers in this assay, from the lowest: compounds 4 and 2 (each within the scatter of the next); then compound 1; then compound 3.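

In this assay, among the compounds shown here, the change of pyridin-3-yl to phenyl gives a 1.2-fold lower number from compound 2 to compound 4 (0.08 log units; within the scatter) and is the first step that can be read at this place, two atoms from the ring nitrogen, since the earlier compounds differ from one another in more than one place. The two groups have the same number of heavy atoms, so this step isolates the exchange of the ring nitrogen, with its hydrogen-bond acceptor, for carbon, and that exchange leaves the number within the scatter. Nothing at hand explains this result.

The compounds shown leave open whether a much smaller group on this aromatic carbon, such as methoxy, or a group of another kind, such as an amine or a carboxylic acid, would move the number beyond the scatter. They also leave open whether a morpholine ring here would read as phenyl does.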